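Changing one side group of compound 1

A few compounds are considered here, and "the series" means these few. Any claim that something is new, unique, unknown or untested is made for them only; others in the source may bear on it.

Compound 1 `COc1ccc(-n2nc(C(=O)Nc3ccncc3)cc2-c2ccc(Cl)cc2)nn1`: 110 nM
Compound 2 `Cn1nc(-c2ccc(Cl)cc2)cc1C(=O)N1CCOCC1`: > 10000 nM (a limit)

Within the data shown here, in a functional assay on a cell-free system (Platelet, plasma, Homo sapiens) for inhibition, read by turbidimetry, with a stated time of 3 min (on this read-out lower numbers stand for stronger inhibition and higher numbers for weaker inhibition), compound 1 gives 110 nM, the only true number so far. For compound 2, this assay gives only a limit, > 10000 nM. Compound 3 `COc1ccc(-n2nc(CCC(=O)N3CCCCC3)cc2-c2ccc(Cl)cc2)nn1` keeps the core of compound 1 and differs at one aromatic carbon: 2-((piperidin-1-yl)carbonyl)ethyl in place of (pyridin-4-yl)carbamoyl on an aromatic carbon. Among the measured compounds shown here, no measured step shows what such a swap does, so any forecast is uncertain. A modest weakening is expected, and the estimated step is a 2.7-fold higher number from compound 1 to compound 3 (0.44 log units; beyond the scatter). Compound 3 is estimated at 300 nM, with an expected range from 40 nM to 2500 nM.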

Compound 3, half-maximal inhibitory concentration: 920 nM
Compound 3: the middle estimate sits 3.1-fold (0.49 log units) below what was measured; measured number inside the range.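

Replacing (pyridin-4-yl)carbamoyl with 2-((piperidin-1-yl)carbonyl)ethyl on this aromatic carbon gives, in this assay, an 8.4-fold higher number from compound 1 to compound 3 (0.92 log units; beyond the scatter). This position is therefore sensitive to the group it carries, yet this change weakens inhibition without abolishing it, as a true number rather than a limit remains. Nothing shown explains the loss.

From the compounds shown here alone, it remains open whether the pyridine ring, the amide hydrogen or the chain matters most. A piperidine amide without the ethyl chain, or a carboxylic acid on this carbon, could help separate these parts.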